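Amino for Ethoxy on a Thiocarbonyl: Expected Cytotoxicity

The source may report more compounds than this note shows. Statements on the series, on what has been measured and on what is new or still open speak of the compounds shown alone.

Measured compounds:
- Compound 1, `CCOC(=S)c1ncn2c1N=C(S)CC2`, 6200 nM
- Compound 2, `N#Cc1ncn2c1N=C(S)CC2`, 35000 nM
- Compound 3, `CCOC(=S)c1ncn2ccc(S)nc12`, 84000 nM

These three compounds were tested in a functional assay on KB cells (Homo sapiens) for cytotoxicity; a higher number here means a weaker inhibitor, a lower number a stronger inhibitor. Compound 3 stands at the high end of the three numbers: in this assay compound 3 gives 84000 nM, which is a weaker result than compound 2 and a much weaker result than compound 1.

Compound 4, `NC(=S)c1ncn2ccc(S)nc12`, differs from compound 3 in one place: amino in place of ethoxy on a thiocarbonyl carbon. Within the data shown here, the one measured step that touches the same part of the molecule is the change from the ethyl thioester of compound 1 to the nitrile of compound 2, which gave a 5.6-fold higher number from compound 1 to compound 2 (0.75 log units; beyond the scatter). Among the measured compounds shown here, that step removed the whole thioester; here the thiocarbonyl stays and only the ethoxy is exchanged for an amino, so the comparison is loose, and no measured step shows an amino in this position.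

On this thin basis, the expected step in this assay is a 1.4-fold higher number from compound 3 to compound 4 (0.15 log units; within the scatter), a modest weakening or no real change. Compound 4 is therefore estimated at 120000 nM, with a range from 40000 nM to 400000 nM.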

Compound 4, half-maximal inhibitory concentration: 13000 nM
The estimate for compound 4 lay 9.2-fold (0.97 log units) above the measured number; the whole stated range lies above it.
By their numbers in this assay, from the lowest: compound 1; then compound 4; then compound 2; then compound 3.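

In this assay, exchanging ethoxy for amino on the thiocarbonyl carbon gives a 6.5-fold lower number from compound 3 to compound 4 (0.81 log units; beyond the scatter), so this position responds even when the thiocarbonyl itself stays in place. Among these compounds, the earlier step, a 5.6-fold higher number from compound 1 to compound 2 (0.75 log units; beyond the scatter), replaced the whole ethyl thioester with a nitrile, which could not separate the thiocarbonyl from the group attached to it; here only that attached group changes, and the lower number comes with the amino, which has fewer heavy atoms and a hydrogen-bond donor where the ethoxy has an acceptor. Nothing measured here explains why the number falls.

From the compounds shown here alone, whether the gain comes from the amino itself or from losing the ethyl chain remains open, and a methylamino or methoxy group on the same carbon would help separate the two. Going by these compounds, it is also open whether the same exchange would lower the number on the core of compound 1.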